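Isoxazolidine-linked chromones: replacing the nitrile with an ester

This account rests on a few compounds, and the source may have more. Where it says the series, first, only, none or still open, it means among the compounds named here.

Measured compounds:
- compound 1, `CCO[C@H]1C[C@@H](c2coc3ccc(Br)cc3c2=O)N(c2ccccc2)O1`, 21500 nM
- compound 2, `Cc1ccc2occ([C@@H]3C[C@H](c4ccccc4)ON3c3ccccc3)c(=O)c2c1`, 49000 nM
- compound 3, `N#C[C@H]1C[C@@H](c2coc3ccc(Cl)cc3c2=O)N(c2ccccc2)O1`, 40000 nM

All three numbers come from a functional assay on A549 cells (Homo sapiens) for inhibition, read by sulforhodamine B assay, with a stated time of 48 h (a lower number here means a stronger inhibitor, a higher number a weaker inhibitor), and all three sit in the weak range. Compound 3 stands second highest of the three; its nearest neighbour is compound 2, whose number lies within the scatter of that of compound 3, and its furthest is compound 1, which also stays within the scatter. On these numbers the three compounds cannot be told apart.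

Compound 4, `COC(=O)[C@H]1C[C@@H](c2coc3ccc(Cl)cc3c2=O)N(c2ccccc2)O1`, has not yet been measured. It differs from compound 3 in one place: methoxycarbonyl in place of cyano on a saturated ring carbon. The change sits on a saturated ring carbon of the five-membered non-aromatic ring, next to the ring oxygen. Among the compounds with values here, no measured pair isolates a change at that ring carbon, so there is no step to lean on. The expectation is therefore no step beyond the scatter, with compound 4 estimated at 35000 nM, range 12000 nM to 90000 nM, and an expected step of a 1.1-fold lower number from compound 3 to compound 4 (0.06 log units; within the scatter) in this assay that stays inside the usual scatter.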

Compound 4, half-maximal inhibitory concentration: > 60000 nM
Compound 4 ended at the assay's limit; the forecaster's own chance of this, stated with the estimate: 15%; middle value at least 1.7-fold (0.23 log units) away from the limit.
By their numbers in this assay, from the lowest: compounds 1, 3 and 2 (each within the scatter of the next, the first and the last beyond it). At a limit, above all of these: compound 4.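

In this assay compound 4 yields a limit of the assay and not a number: the limit of > 60000 nM in this assay, at which 1 of the 4 values shown sits.

Methoxycarbonyl in place of cyano on this saturated ring carbon, next to the ring oxygen, gives an at least 1.5-fold higher number from compound 3 to compound 4 (0.17 log units; that floor lies within the scatter), the first readable step at this position. From the compounds shown here alone, the step shows no sign of a stronger inhibitor with this change, but its true size remains unknown, as only its floor is available.

Compounds 1 and 2 differ from compound 3 in more than one place, so steps involving them cannot be read and the contribution of the other groups at this ring carbon remains unresolved. Also open, going by these compounds, is whether an amine, a carboxylic acid or a longer chain at this ring carbon would give a number clearly apart from that of compound 3.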